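This account rests on a few compounds, and the source may have more. Where it says the series, first, only, none or still open, it means among the compounds named here.

Of the compounds shown here, three have been measured so far in a functional assay on DU-145 cells (Homo sapiens) for inhibition, read by trypan blue exclusion, with a stated time of 96 h (a lower number here means a stronger inhibitor of growth, a higher number a weaker inhibitor of growth), and give these values.

Compound 1 `CCOc1ccc(/C=C(\C(=O)c2ccc(Cl)cc2)S(=O)(=O)Cc2ccc(C)cc2)cc1OC` gives 10000 nM here.
Compound 2 `Cc1ccc(/C=C(\C(=O)c2ccc(Cl)cc2)S(=O)(=O)Cc2ccc(Cl)cc2Cl)s1` gives 10000 nM here.
Compound 3 `Cc1ccc(CS(=O)(=O)/C(=C/c2cc(C)ccc2C)C(=O)c2ccc(Cl)cc2)cc1` gives 1000 nM here.

Compound 3 holds the lowest number of the three, and compounds 1 and 2 both give higher numbers, beyond the scatter. The next compound, compound 4 `Cc1ccc(CS(=O)(=O)/C(=C/c2ccc(C)s2)C(=O)c2ccc(Cl)cc2)cc1`, has not yet been measured. It differs from compound 3 by having 5-methylthiophen-2-yl in place of 2,5-dimethylphenyl on a double-bonded chain carbon bound to a double-bonded chain carbon.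

For the measured compounds named here, only one measured step changes this same place. This is a 10-fold lower number from compound 1 to compound 3 (1.00 log units; beyond the scatter) and it shows that the group here can shift the number by a modest amount. Going by the values given here, compound 2 already carries 5-methylthiophen-2-yl and gives 10000 nM here, but it differs from compound 4 elsewhere too, so no measured step isolates this exchange. Among the compounds with values here, a move towards a higher number in this assay is therefore expected, though smaller than the one step seen. The estimated change is a 3.0-fold higher number from compound 3 to compound 4 (0.48 log units; beyond the scatter) in this read-out. For compound 4 the expected value is 3000 nM with an estimated range from 800 nM to 10000 nM as the likely span.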

Compound 4, concentration for 50% growth inhibition: 25000 nM
Beside the measured number, compound 4's estimate is 8.3-fold (0.92 log units) below it; the measured number lies above the stated range.
By their numbers in this assay, from the lowest: compound 3; then compounds 1 and 2 (each within the scatter of the next); then compound 4.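

In this assay, for the compounds shown here, the exchange of 2,5-dimethylphenyl for 5-methylthiophen-2-yl gives a 25-fold higher number from compound 3 to compound 4 (1.40 log units; beyond the scatter), larger than the only step earlier seen at this place, and a 2.5-fold higher number from compound 1 to compound 4 (0.40 log units; beyond the scatter) shows that 5-methylthiophen-2-yl also gives a higher number than 4-ethoxy-3-methoxyphenyl, so the three groups on the double-bonded chain carbon now fall into an order beyond the scatter, with 2,5-dimethylphenyl giving the lowest number and 5-methylthiophen-2-yl the highest. With 5-methylthiophen-2-yl held in place, a 2.5-fold higher number from compound 2 to compound 4 (0.40 log units; beyond the scatter) comes from 4-methylphenyl in place of 2,4-dichlorophenyl on a saturated chain carbon bound to a sulfonyl sulfur, so the number also responds to that second place, though by a smaller step. Nothing available explains why these exchanges move the number as they do.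

The compounds shown leave open whether the low number of compound 3 depends on its two methyl groups or on the six-membered ring that carries them, a question that an unsubstituted phenyl, a 2-methylphenyl or a 3-methylphenyl group at the same place would address. They also leave open whether 2,5-dimethylphenyl keeps its advantage when 2,4-dichlorophenyl stands on the saturated chain carbon.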